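Chloropyridine amide follows two chloroalkyl amides

The source may report more compounds than this note shows. Statements on the series, on what has been measured and on what is new or still open speak of the compounds shown alone.

Compound 1 `CC(Cl)C(=O)Nc1cccc(-c2nc3ccccc3s2)c1` reaches only the assay limit in an ADME assay on HepG2 cells (Homo sapiens) for inhibition, with a stated time of 72 h (on this read-out lower numbers stand for an effect already at smaller amounts and higher numbers for an effect only at larger amounts of compound), namely > 25000 nM.
Compound 2 `CC(C)(CCl)C(=O)Nc1cccc(-c2nc3ccccc3s2)c1` likewise sits at the limit in this assay, at > 25000 nM.

Compound 2 therefore stands at the limit, and the limit of > 25000 nM in this assay, at which 2 of the 2 values shown sit, shows both measured values there. The step that the two limits leave unreadable from compound 1 to compound 2 is accordingly unreadable. Compound 3 `O=C(Nc1cccc(-c2nc3ccccc3s2)c1)c1cnccc1Cl` differs from compound 2 by 4-chloropyridin-3-yl in place of 1-(chloromethyl)-1-methylethyl on a carbonyl carbon. No measured step is readable, so no direction can be drawn from the shown data. The estimated step of a number no higher from compound 2 to compound 3 (the limit leaves the size open) is centred on the limit. Compound 3 is expected at 25000 nM, with a range from 4000 nM to 120000 nM.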

Compound 3, half-maximal effective concentration: > 25000 nM
Compound 3: only a limit was reported; the forecaster's own chance of this, stated with the estimate: 65%; the middle value sits exactly at the limit.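

Among these compounds, compound 3 also reaches only a limit in this assay, so no step among compound 1, compound 2 and compound 3 can be read: the limit of > 25000 nM in this assay, at which 3 of the 3 values shown sit.

The compounds shown leave open which group on the carbonyl carbon, if any, would give a measurable effect in this assay and how these three compounds rank.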